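The source may hold more compounds than are shown below. What is called first, only, known or untested is meant among the compounds shown, and "the series" means these compounds.

Measured compounds:
Compound 1 `COc1cc(CCc2ccc(F)cc2)cc(OC)c1O`: in a functional assay on MKN-45 cells (Homo sapiens) for antiproliferative activity, read by MTT assay, with a stated time of 72 h (on this read-out higher numbers stand for weaker inhibition and lower numbers for stronger inhibition), compound 1 gives 10700 nM.
Compound 2 `COc1cc(CCc2ccc(Cl)cc2)cc(OC)c1O`: in this assay compound 2 reaches only the limit of the assay, > 25000 nM.

Compound 2 therefore stands at the limit (the limit of > 25000 nM in this assay, at which 1 of the 2 values shown sits), and no number is known for it. Among the measured compounds shown here, the one measured step, an at least 2.3-fold higher number from compound 1 to compound 2 (0.36 log units; beyond the scatter), shows that the exchange of fluoro for chloro made the number larger, though only a bound is known at its far end.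

Compound 3 `COc1cc(CCc2ccc([N+](=O)[O-])cc2)cc(OC)c1O` differs from compound 2 by nitro in place of chloro on an aromatic carbon. For the measured compounds named here, no measured step concerns a nitro group, so the step from compound 2 to compound 3 has no direct precedent; the only step available, an at least 2.3-fold higher number from compound 1 to compound 2 (0.36 log units; beyond the scatter), describes a different exchange. Compound 3 is therefore expected, with wide uncertainty, to give about 25000 nM, within a range from 8000 nM to 80000 nM. That estimate amounts to an expected step of a number no higher from compound 2 to compound 3 (the limit leaves the size open), quite possibly again only a limit.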

Compound 3, half-maximal inhibitory concentration: 15400 nM
For compound 3 the middle estimate is 1.6-fold (0.21 log units) above the measured one, within the range that was stated.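

In this assay, nitro in place of chloro, para to a large group, restores a measured number and gives an at least 1.6-fold lower number from compound 2 to compound 3 (0.21 log units; that floor lies within the scatter). Compound 2 is held only by a limit, so this step has a floor and no known size: the limit of > 25000 nM in this assay, at which 1 of the 3 values shown sits. Nitro and fluoro at this position cannot be told apart, as the exchange gives a 1.4-fold higher number from compound 1 to compound 3 (0.16 log units; within the scatter), so two different groups here leave the number within the scatter of each other while chloro alone ends at the limit.

As far as these compounds go, it remains open how far compound 2 really lies from compound 1 and compound 3. Also open, from the compounds shown here alone, is whether an amine, a carboxylic acid or a longer chain at this position would give a number clearly apart from theirs.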